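A few compounds are considered here, and "the series" means these few. Any claim that something is new, unique, unknown or untested is made for them only; others in the source may bear on it.

Compound 1 `O=C(Nc1ccc(Cl)c(-c2nnc3c(Cl)cccn23)c1)c1ccc(F)cc1Cl` reaches only the limit of > 100000 nM in a functional assay on MDA-MB-468 cells (Homo sapiens) for antiproliferative activity, read by MTT assay, with a stated time of 72 h; a higher number here means a weaker inhibitor, a lower number a stronger inhibitor. Compound 2 `CS(=O)(=O)c1ccc(C(=O)Nc2ccc(Cl)c(-c3nnc4c(Cl)cccn34)c2)cc1` likewise stops at the limit of > 100000 nM in this assay. Compound 3 `O=C(Nc1ccc(Cl)c(-c2nnc3c(Cl)cccn23)c1)c1ccc(Cl)cc1Cl` gives 21600 nM in this assay.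

Compound 3 thus carries the only number shown; the other two values are limits (the limit of > 100000 nM in this assay, at which 2 of the 3 values shown sit). Compound 4 `O=C(Nc1ccc(Cl)c(-c2nnc3c(Cl)cccn23)c1)c1c(F)cccc1Cl` carries 2-chloro-6-fluorophenyl in place of 2,4-dichlorophenyl on a carbonyl carbon. Going by the values given here, two measured steps bear on it: an at least 4.6-fold lower number from compound 1 to compound 3 (0.66 log units; beyond the scatter), and an at least 4.6-fold lower number from compound 2 to compound 3 (0.66 log units; beyond the scatter). Both show that the 2,4-dichlorophenyl of compound 3 is what lifts the value off the limit, and compound 4 gives that group up for a ring with a fluoro in it, as compound 1 has. Compound 4 is therefore expected to move back toward the limit, by a 3.2-fold higher number from compound 3 to compound 4 (0.51 log units; beyond the scatter), with an estimated 70000 nM (range 20000 nM to 250000 nM).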

Compound 4, half-maximal inhibitory concentration: 57600 nM
Compound 4: the middle estimate sits 1.2-fold (0.08 log units) above what was measured; the range from low to high includes it.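

With a 2.7-fold higher number from compound 3 to compound 4 (0.43 log units; beyond the scatter), 2-chloro-6-fluorophenyl on a carbonyl carbon gives up activity against 2,4-dichlorophenyl, yet a ring carrying fluoro can still yield a number. Compound 4 is the only fluoro-bearing compound shown to do so in this assay. Its distance from the others is not sized, since an at least 1.7-fold lower number from compound 1 to compound 4 (0.23 log units; that floor lies within the scatter) and an at least 1.7-fold lower number from compound 2 to compound 4 (0.23 log units; that floor lies within the scatter) are only floors set by a limit: the limit of > 100000 nM in this assay, at which 2 of the 4 values shown sit. The compounds shown leave open whether a ring carrying an amine, a carboxylic acid or a methoxy group at this place would match 2,4-dichlorophenyl.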